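The source may report more compounds than this note shows. Statements on the series, on what has been measured and on what is new or still open speak of the compounds shown alone.

Compound 2 `Fc1ccccc1N1CCN(Cn2nc(-c3ccc4c(c3)OCCO4)oc2=S)CC1` is one of three analogues sharing a core in which a substituted phenyl sits on an amine nitrogen in a ring. In a functional assay on BGC-823 cells (Homo sapiens) for antiproliferative activity, read by MTT assay, with a stated time of 48 h (a higher number here means a weaker inhibitor, a lower number a stronger inhibitor), compound 2 gives only a limit of the assay, > 50000 nM, and so stands at the weak end of the set (the limit of > 50000 nM in this assay, at which 1 of the 3 values shown sits). Compound 1 `Cc1ccc(N2CCN(Cn3nc(-c4ccc5c(c4)OCCO5)oc3=S)CC2)c(C)c1` gives 28300 nM in this assay, and compound 3 `COc1ccccc1N1CCN(Cn2nc(-c3ccc4c(c3)OCCO4)oc2=S)CC1` gives 19500 nM. The steps of an at least 1.7-fold higher number from compound 1 to compound 2 (0.24 log units; that floor lies within the scatter) and a 1.5-fold lower number from compound 1 to compound 3 (0.16 log units; within the scatter) stay within the scatter, whereas an at least 2.5-fold lower number from compound 2 to compound 3 (0.40 log units; beyond the scatter) is at least modest. Compound 4 `COc1ccc(N2CCN(Cn3nc(-c4ccc5c(c4)OCCO5)oc3=S)CC2)cc1` differs from compound 2 by 4-methoxyphenyl in place of 2-fluorophenyl on an amine nitrogen in a ring. Because of an at least 2.5-fold lower number from compound 2 to compound 3 (0.40 log units; beyond the scatter), a step of similar size is expected, namely an at least 2.5-fold lower number from compound 2 to compound 4 (0.39 log units; beyond the scatter). Compound 4 is therefore estimated at 20000 nM in this assay, between 8000 nM and 50000 nM.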

Compound 4, half-maximal inhibitory concentration: 18900 nM
Compound 4: middle estimate off by 1.1-fold (0.02 log units), on the high side; the range from low to high includes it.
By their numbers in this assay, from the lowest: compounds 4, 3 and 1 (each within the scatter of the next). At a limit, above all of these: compound 2.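

In this assay, moving the methoxy group from 2-methoxyphenyl to 4-methoxyphenyl registers no difference, with a 1.0-fold lower number from compound 3 to compound 4 (0.01 log units; within the scatter), and the change from 2,4-dimethylphenyl also stays within the scatter, with a 1.5-fold lower number from compound 1 to compound 4 (0.18 log units; within the scatter). A second methoxyphenyl compound now separates from the 2-fluorophenyl compound, with an at least 2.6-fold lower number from compound 2 to compound 4 (0.42 log units; beyond the scatter). Compound 2 gives only a limit of the assay: the limit of > 50000 nM in this assay, at which 1 of the 4 values shown sits.

Going by these compounds, whether 4-fluorophenyl would stand with compound 2 or with the methoxyphenyl compounds remains open. So does the outcome for a carboxylic acid or an amine on the phenyl ring.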